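Benzyl for chlorophenyl on a compound already at the limit

This account rests on a few compounds, and the source may have more. Where it says the series, first, only, none or still open, it means among the compounds named here.

Compound 1 is `COc1ccc(Cc2cc(-c3ccc(Cl)cc3)nn(CC(=O)Nc3ccc(Br)cc3)c2=O)cc1`. In a functional assay on HL-60 cells (Homo sapiens), read by calcium flux (a lower number here means that less compound is needed, a higher number that more compound is needed for the effect), compound 1 gives > 50000 nM, which is a limit of the assay rather than a number. Compound 2, `COc1cccc(Cc2cc(-c3ccc(Cl)cc3)nn(CC(=O)Nc3ccc(F)cc3)c2=O)c1`, gives in this assay > 50000 nM, again a limit. Compound 3, `COc1cccc(Cc2cc(-c3ccc(F)cc3)nn(CC(=O)Nc3ccc(F)cc3)c2=O)c1`, gives in this assay > 50000 nM, also a limit. For the measured compounds named here, the one step between measured neighbours, a step that the two limits leave unreadable from compound 2 to compound 3, therefore cannot be read for size or direction. the limit of > 50000 nM in this assay, at which 3 of the 3 values shown sit: every value shown so far is a limit, so compound 1 stands nowhere on a scale of numbers, only at the ceiling it shares with compounds 2 and 3.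

Compound 4 is `COc1ccc(Cc2cc(Cc3ccccc3)nn(CC(=O)Nc3ccc(Br)cc3)c2=O)cc1`. It differs from compound 1 by benzyl in place of 4-chlorophenyl on an aromatic carbon. Going by the values given here, no measured step concerns this change, and the only measured step, a step that the two limits leave unreadable from compound 2 to compound 3, is unreadable, so there is no size to carry over. The expectation for compound 4 in this assay is thus an estimate of 50000 nM, with a range from 10000 nM to 200000 nM, and most probably a further limit. The step this implies, a number no higher from compound 1 to compound 4 (the limit leaves the size open), is expected to show nothing beyond the scatter; nothing among compounds 1, 2 and 3 shows that any change in this series moves the read-out.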

Compound 4, half-maximal effective concentration: > 50000 nM
Compound 4 was reported as a limit; the forecaster's own chance of this, stated with the estimate: 85%; the middle value sits exactly at the limit.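

Compound 4, like compound 1, sits at a limit of the assay, so the change from 4-chlorophenyl to benzyl between them cannot be read for size or direction. The compounds shown leave open whether any change on the shared core moves the read-out at all: the limit of > 50000 nM in this assay, at which 4 of the 4 values shown sit.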